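Swapping a Methoxyethyl Chain for a Methylpyrimidine Ring

The source may hold more compounds than are shown below. What is called first, only, known or untested is meant among the compounds shown, and "the series" means these compounds.

In a functional assay on HT-29 cells (Homo sapiens) for inhibition, read by luminescence and CellTiter-Glo, with a stated time of 24 h (on this read-out higher numbers stand for an effect only at larger amounts of compound and lower numbers for an effect already at smaller amounts), three compounds of a shared core have been measured:

Compound 1 `CN1C(=S)[C@@H](NC(=O)c2nc(Cc3ccccc3)n(CCCF)n2)COc2ccccc21`: 4760 nM
Compound 2 `COCCn1nc(C(=O)N[C@H]2COc3ccccc3N(C)C2=S)nc1Cc1ccccc1`: 566 nM
Compound 3 `CN1C(=S)[C@@H](NC(=O)c2nc(Cc3ccccc3)n(C3CCCCCC3)n2)COc2ccccc21`: 5530 nM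

Compound 2 has the lowest number of the three. Its nearest neighbour is compound 1, separated by the step of an 8.4-fold lower number from compound 1 to compound 2 (0.92 log units; beyond the scatter), and its furthest is compound 3, separated by the step of a 9.8-fold higher number from compound 2 to compound 3 (0.99 log units; beyond the scatter).

Compound 4 `Cc1cnc(-n2nc(C(=O)N[C@H]3COc4ccccc4N(C)C3=S)nc2Cc2ccccc2)nc1` differs from compound 2 in one place: 5-methylpyrimidin-2-yl in place of 2-methoxyethyl on an aromatic nitrogen. Both measured steps touch this same position. Each group other than 2-methoxyethyl on that aromatic nitrogen gave a higher number, whether fluoromethyl in the step of an 8.4-fold lower number from compound 1 to compound 2 (0.92 log units; beyond the scatter) read backwards, or cycloheptyl in the step of a 9.8-fold higher number from compound 2 to compound 3 (0.99 log units; beyond the scatter). The entering 5-methylpyrimidin-2-yl is again a change away from 2-methoxyethyl, though it counts 2 hydrogen-bond acceptors, so a higher number beyond the scatter is expected, of uncertain size.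

For compound 4 the expected number is 2000 nM, estimated to lie from 600 nM to 7000 nM. This estimate means an expected step of a 3.5-fold higher number from compound 2 to compound 4 (0.55 log units; beyond the scatter).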

Compound 4, half-maximal effective concentration: 1950 nM
The estimate for compound 4 lay 1.0-fold (0.01 log units) above the measured number; low and high end bracket the measured number.
By their numbers in this assay, from the lowest: compound 2; then compound 4; then compounds 1 and 3 (each within the scatter of the next).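

On this aromatic nitrogen, 2-methoxyethyl still gives the lowest number in this assay, with a 3.4-fold higher number from compound 2 to compound 4 (0.54 log units; beyond the scatter) beyond the scatter, so this six-membered aromatic ring does not match the chain. The ring nevertheless gives a lower number than either other group, with a 2.8-fold lower number from compound 3 to compound 4 (0.45 log units; beyond the scatter) and a 2.4-fold lower number from compound 1 to compound 4 (0.39 log units; beyond the scatter) both beyond the scatter. The position therefore shows three separate levels among these four compounds, rather than 2-methoxyethyl standing apart from everything else, and no measurement at hand accounts for this order.

Still open, going by these compounds, is whether the ring as such or its methyl group sets the level of compound 4, which pyrimidin-2-yl and phenyl could help to separate. On these data alone, it is also open how much the oxygen of compound 2 matters, a question for 2-hydroxyethyl or a longer 3-methoxypropyl chain.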